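Cyano to acetamido in a flat series

The source may report more compounds than this note shows. Statements on the series, on what has been measured and on what is new or still open speak of the compounds shown alone.

In a functional assay on SMMC-7721 cells (Homo sapiens) for cytotoxicity, read by MTT assay, with a stated time of 24 h (a lower number here means a stronger inhibitor, a higher number a weaker inhibitor), three compounds sharing one core have been measured. Compound 1 `O=C1/C(=C/c2ccncc2)CN(S(=O)(=O)c2ccc([N+](=O)[O-])cc2)C/C1=C\c1ccccc1F` gives 15800 nM, compound 2 `O=C1/C(=C/c2ccncc2)CN(S(=O)(=O)c2ccc(Br)cc2)C/C1=C\c1ccccc1F` gives 12600 nM, and compound 3 `N#Cc1ccc(S(=O)(=O)N2C/C(=C\c3ccncc3)C(=O)/C(=C/c3ccccc3F)C2)cc1` gives 16200 nM. Compound 3 therefore stands level with the other two, all within the scatter.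

Compound 4 `CC(=O)Nc1ccc(S(=O)(=O)N2C/C(=C\c3ccncc3)C(=O)/C(=C/c3ccccc3F)C2)cc1` has acetamido in place of cyano on an aromatic carbon, para to a large group: acetamido in place of cyano on an aromatic carbon.

The three measured steps all fall at this same place: a 1.3-fold lower number from compound 1 to compound 2 (0.10 log units; within the scatter), a 1.0-fold higher number from compound 1 to compound 3 (0.01 log units; within the scatter) and a 1.3-fold higher number from compound 2 to compound 3 (0.11 log units; within the scatter). Each lies within the scatter, so nitro, bromo and cyano cannot be told apart here. For the measured compounds named here, no measured compound carries acetamido, which leaves the direction open and the range wide. No step beyond the scatter is expected in this assay. The estimated step is a 1.1-fold lower number from compound 3 to compound 4 (0.03 log units; within the scatter). For compound 4 the expected value is 15000 nM, with an estimated range of 7000 nM to 32000 nM.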

Compound 4, half-maximal inhibitory concentration: 13400 nM
For compound 4 the middle estimate is 1.1-fold (0.05 log units) above the measured one; measured number inside the range.
By their numbers in this assay, from the lowest: compounds 2, 4, 1 and 3 (each within the scatter of the next).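

In this assay, acetamido on this aromatic carbon, para to a large group, cannot be told apart from the three groups already seen: cyano (a 1.2-fold lower number from compound 3 to compound 4 (0.08 log units; within the scatter)), bromo (a 1.1-fold higher number from compound 2 to compound 4 (0.03 log units; within the scatter)) and nitro (a 1.2-fold lower number from compound 1 to compound 4 (0.07 log units; within the scatter)), each step within the scatter. The change from cyano to acetamido goes from 2 heavy atoms to 4 and adds 1 hydrogen-bond donor, yet it gives no readable step, so this place now tolerates a wider range of groups than nitro, bromo and cyano alone showed. No supporting evidence is available to explain this lack of separation.

Going by these compounds, whether an amine, a carboxylic acid or a longer chain at this place would give a step beyond the scatter remains open. On these data alone, all four compounds share the rest of the core, so whether this place stays equally insensitive with changes elsewhere on the core also remains open.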